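Ethoxy in Place of Bromo on a Hydrazone Aryl Ring

The compounds below may be only part of what the source reports. "The series", "measured", "known", "first", "only" and "open" are said of these compounds alone.

Measured so far:
compound 1 `CC1CC/C(=N\Nc2ccccc2Br)c2ncc(C(=O)O)c(=O)n21` gives > 320 umol/kg
compound 2 `CC1CC/C(=N\Nc2cccc(Br)c2)c2ncc(C(=O)O)c(=O)n21` gives > 320 umol/kg

In a functional assay on the whole organism for inhibition, with Rattus norvegicus as the target (on this read-out higher numbers stand for an effect only at larger amounts of compound and lower numbers for an effect already at smaller amounts), compound 1 gives > 320 umol/kg, which is a limit of the assay and not a number. Compound 2 gives > 320 umol/kg, likewise only a limit. The step that the two limits leave unreadable from compound 1 to compound 2 therefore cannot be read in size or direction. Among the compounds with values here, the only evidence is the limit of > 320 umol/kg in this assay, at which 2 of the 2 values shown sit.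

Compound 3 `CCOc1ccccc1N/N=C1\CCC(C)n2c1ncc(C(=O)O)c2=O` differs from compound 1 by ethoxy in place of bromo on an aromatic carbon. Within the data shown here, no measured step bears on this change, and none of the measured values is a number, so no size or direction can be taken from them. Compound 3 is therefore expected to sit where compound 1 sits, with an estimated value of 400 umol/kg, ranging from 150 umol/kg to 1500 umol/kg, and the step that the limit leaves unreadable from compound 1 to compound 3 is expected to be nothing beyond the scatter, most likely again reported only as a limit.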

Compound 3, dose for 50% inhibition: > 1000 umol/kg
Compound 3 was reported as a limit; the forecaster's own chance of this, stated with the estimate: 75%; middle value at least 2.5-fold (0.39 log units) from the limit.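

Compound 1 and compound 3 are each known only through a limit of the assay, not a number, so the step between them cannot be read in size or direction. The compounds shown leave open how ethoxy and bromo compare at this aromatic carbon.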